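This account rests on a few compounds, and the source may have more. Where it says the series, first, only, none or still open, it means among the compounds named here.

Working notes on the hydrazone series. All four members share one core and differ only in the group on the nitrogen on the aromatic ring. Compound 1 `CCCSc1nc(N/N=C/c2ccccc2Cl)c2nnn(Cc3ccccc3)c2n1` bears a 2-chlorophenyl on a carbon with a double bond to nitrogen; in a functional assay on ECa-109 cells (Homo sapiens) for antiproliferative activity, read by MTT assay, with a stated time of 72 h (on this read-out lower numbers stand for stronger inhibition and higher numbers for weaker inhibition), compound 1 gives 6180 nM. Compound 2 `CCCSc1nc(N/N=C/c2ccc3ccccc3c2)c2nnn(Cc3ccccc3)c2n1` bears naphthalen-2-yl in that place. In this assay compound 2 reaches only > 64000 nM, a limit of the assay and not a number (the limit of > 64000 nM in this assay, at which 1 of the 3 values shown sits). Compound 3 `CCCSc1nc(N/N=C(\C)c2ccccc2)c2nnn(Cc3ccccc3)c2n1` gives 32200 nM in this assay, the highest of the two numbers shown; the nearest is compound 1, and the step of a 5.2-fold higher number from compound 1 to compound 3 (0.72 log units; beyond the scatter) is beyond the scatter. The step of an at least 10-fold higher number from compound 1 to compound 2 (1.01 log units; beyond the scatter) is larger still.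

Compound 4 `CCCSc1nc(N/N=C/c2ccc(Br)cc2)c2nnn(Cc3ccccc3)c2n1` differs from compound 3 by a group of 9 heavy atoms (7 carbon, 1 nitrogen, 1 bromine; one six-membered aromatic ring of carbon only) in place of a group of 9 heavy atoms (8 carbon, 1 nitrogen; one six-membered aromatic ring of carbon only), on a nitrogen on an aromatic ring. Within the data shown here, two measured steps bear on it. The step of a 5.2-fold higher number from compound 1 to compound 3 (0.72 log units; beyond the scatter) runs in the opposite sense, from a halogen-bearing ring to the methyl-bearing group, and was modest. The step of an at least 10-fold higher number from compound 1 to compound 2 (1.01 log units; beyond the scatter) warns that enlarging the ring system costs heavily, but compound 4 keeps a single six-membered ring. The change is therefore expected to roughly reverse the first step, giving a lower number, a 4.0-fold lower number from compound 3 to compound 4 (0.60 log units; beyond the scatter). Compound 4 is expected near 8000 nM, within 3000 nM to 25000 nM.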

Compound 4, half-maximal inhibitory concentration: > 64000 nM
Compound 4 gave a limit, no number; the forecaster's own chance of this, stated with the estimate: 10%; at least 8.0-fold (0.90 log units) between middle value and limit.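

In this assay, among these compounds, compound 4 stands at a limit of the assay and not a number, so a single six-membered ring on the carbon with a double bond to nitrogen does not by itself keep the number low, and naphthalen-2-yl is no longer the only group in this place to end at the limit. The step of an at least 10-fold higher number from compound 1 to compound 4 (1.01 log units; beyond the scatter) shows that 4-bromophenyl cannot stand in for 2-chlorophenyl here, so carrying a halogen on the ring does not alone preserve the activity of the compound with 2-chlorophenyl. The step of an at least 1.9-fold higher number from compound 3 to compound 4 (0.29 log units; that floor lies within the scatter) has a floor within the scatter and sets no order between those two compounds, and the step between compound 2 and compound 4 cannot be read, as both are limits: the limit of > 64000 nM in this assay, at which 2 of the 4 values shown sit.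

2-Chlorophenyl and 4-bromophenyl differ in both the halogen and its place on the ring, so the compounds shown do not separate these two changes. From the compounds shown here alone, how an unsubstituted phenyl on the same carbon, or a phenyl ring carrying an amine or a carboxylic acid, would fall in this assay remains open.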